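Amide to Acid on Two Aryl-Pyridine Cores

The source may hold more compounds than are shown below. What is called first, only, known or untested is meant among the compounds shown, and "the series" means these compounds.

Measured so far:
compound 1, `CNC(=O)CCc1ccncc1-c1ccc2ccccc2c1`: > 10000 nM
compound 2, `O=C(O)CCc1ccncc1-c1ccc2ccccc2c1`: > 10000 nM
compound 3, `CNC(=O)/C=C/c1ccncc1-c1ccc2[nH]ccc2c1`: > 10000 nM

In a functional assay on KB cells (Homo sapiens) for inhibition, read by sulforhodamine B assay, with a stated time of 72 h (a higher number here means a weaker inhibitor of growth, a lower number a stronger inhibitor of growth), compound 1 gives > 10000 nM, which is a limit of the assay and not a number. Compound 2 likewise stands at a limit, > 10000 nM. Compound 3 also reaches only a limit, > 10000 nM. The change from compound 1 to compound 2 is hydroxy in place of methylamino on a carbonyl carbon, and its step is a step that the two limits leave unreadable from compound 1 to compound 2, unreadable because of the limit of > 10000 nM in this assay, at which 3 of the 3 values shown sit.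

Compound 4, `O=C(O)/C=C/c1ccncc1-c1ccc2[nH]ccc2c1`, is not yet measured. It differs from compound 3 by hydroxy in place of methylamino on a carbonyl carbon, the same kind of change as from compound 1 to compound 2, though the carbonyl carbon there neighbours a saturated chain carbon and here a double-bonded chain carbon. How the core of compound 3 differs from the core of compound 1 is not broken down here.

Compound 4 is expected in this assay to sit near 30000 nM, between 10000 nM and 100000 nM, most likely again only as a limit. The expected step is a step that the limit leaves unreadable from compound 3 to compound 4, resting on the fact that compound 1 and compound 2 both fall at the same limit because of the limit of > 10000 nM in this assay, at which 3 of the 3 values shown sit.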

Compound 4, concentration for 50% growth inhibition: > 10000 nM
Compound 4 was reported as a limit; the forecaster's own chance of this, stated with the estimate: 90%; the middle value is on the limit's open side.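

No step can be read from compound 3 to compound 4, because each compound reaches only a limit: the limit of > 10000 nM in this assay, at which 4 of the 4 values shown sit. The compounds shown leave open whether hydroxy in place of methylamino on a carbonyl carbon changes anything in this assay.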